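Sulfonyl hydrazide series: replacing the aryl bromide

This account rests on a few compounds, and the source may have more. Where it says the series, first, only, none or still open, it means among the compounds named here.

Measured so far:
compound 1 `CC(=O)Nc1ccc(S(=O)(=O)NNc2ccc(Br)cc2)cc1`: 85 nM
compound 2 `CC(=O)Nc1ccc(S(=O)(=O)NNc2ccc(Br)c(F)c2)cc1`: 187 nM
compound 3 `O=S(=O)(NNc1ccc(Br)cc1)c1ccc(Br)cc1`: 374 nM

In an assay on HeLa cells for inhibition of Indoleamine 2,3-dioxygenase 1 (Homo sapiens), read by spectrophotometry, with a stated time of 24 h (on this read-out lower numbers stand for an effect already at smaller amounts and higher numbers for an effect only at larger amounts of compound), compound 3 gives the highest number of the three; its nearest neighbour is compound 2, and the gap between them is within the scatter, whereas the step of a 4.4-fold higher number from compound 1 to compound 3 (0.64 log units; beyond the scatter) lies beyond it. The next compound, compound 4 `COC(=O)CCc1ccc(S(=O)(=O)NNc2ccc(Br)cc2)cc1`, differs from compound 3 by one change: 2-(methoxycarbonyl)ethyl in place of bromo on an aromatic carbon. For the measured compounds named here, no measured step covers this exact exchange. The step of a 4.4-fold higher number from compound 1 to compound 3 (0.64 log units; beyond the scatter) is the only one at this site of the shared core and shows that acetamido gave a lower number there than bromo; the step of a 2.2-fold higher number from compound 1 to compound 2 (0.34 log units; beyond the scatter) concerns the other ring and does not bear on it. The entering group, like acetamido in compound 1, brings oxygen rather than a halogen, and a move back toward the number of compound 1 is expected for compound 4. Nothing measured tells how an ester chain compares with acetamido, and the expected move is kept smaller than that step. The step expected here is a 2.3-fold lower number from compound 3 to compound 4 (0.37 log units; beyond the scatter). Compound 4 is expected at 160 nM, within 50 nM to 500 nM.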

Compound 4, half-maximal effective concentration: 465 nM
Estimate against measurement, compound 4: 2.9-fold (0.46 log units) below; low and high end bracket the measured number.
By their numbers in this assay, from the lowest: compound 1; then compounds 2, 3 and 4 (each within the scatter of the next, the first and the last beyond it).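

In this assay, 2-(methoxycarbonyl)ethyl in place of bromo gives a 1.2-fold higher number from compound 3 to compound 4 (0.09 log units; within the scatter) and the two groups are not told apart at this position, so oxygen and hydrogen-bond acceptors in the entering group do not by themselves bring the number back toward that of compound 1. Acetamido is now the only group at this position set apart from the others, with a 5.5-fold higher number from compound 1 to compound 4 (0.74 log units; beyond the scatter) alongside a 4.4-fold higher number from compound 1 to compound 3 (0.64 log units; beyond the scatter) in the series. No evidence at hand bears on this result.

Open, as far as these compounds go, is which part of acetamido matters: a plain amine, or a propanamide chain with the amide hydrogen kept, would separate the nitrogen from the carbonyl. Also open, from the compounds shown here alone, is whether a carboxylic acid in place of the methyl ester, or a longer chain, would leave the number where the ester chain puts it.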